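Replacing 3-methoxyphenyl with 4-methylphenyl

The compounds below may be only part of what the source reports. "The series", "measured", "known", "first", "only" and "open" are said of these compounds alone.

In an ADME assay on Vero cells (Chlorocebus sabaeus) for cytotoxicity, read by MTT assay (on this read-out lower numbers stand for stronger inhibition and higher numbers for weaker inhibition), compound 2 `C=CCOc1cc(OC)c(C(=O)/C=C/c2cccc(OC)c2)c(OCC=C)c1` gives 142000 nM, the higher of the two numbers available. Compound 1 `C=CCOc1cc(OC)c(C(=O)/C=C/c2ccc(F)cc2)c(OCC=C)c1` gives 13600 nM, while compound 3 `COc1ccc(/C=C/C(=O)c2c(O)cc(O)cc2OC)cc1` has no number, its entry reading "not determined" (no result reported). Compound 4 `C=CCOc1cc(OC)c(C(=O)/C=C/c2ccc(C)cc2)c(OCC=C)c1` awaits measurement and differs from compound 2 by 4-methylphenyl in place of 3-methoxyphenyl on a double-bonded chain carbon bound to a double-bonded chain carbon. Within the data shown here, one measured step bears on this change: a 10-fold higher number from compound 1 to compound 2 (1.02 log units; beyond the scatter), large and beyond the scatter, with 3-methoxyphenyl replacing 4-fluorophenyl. On that single step, a move to a lower number is expected, a 4.7-fold lower number from compound 2 to compound 4 (0.68 log units; beyond the scatter), in this assay. The estimate for compound 4 is 30000 nM, with an expected range from 9000 nM to 100000 nM.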

Compound 4, half-maximal inhibitory concentration: 211000 nM
For compound 4 the middle estimate is 7.0-fold (0.85 log units) below the measured one; measured number above the stated range.
By their numbers in this assay, from the lowest: compound 1; then compounds 2 and 4 (each within the scatter of the next).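

In this assay, the change at this place makes no difference that can be read: a 1.5-fold higher number from compound 2 to compound 4 (0.17 log units; within the scatter), so 4-methylphenyl and 3-methoxyphenyl cannot be told apart here. The large step lies elsewhere, with methyl in place of fluoro on an aromatic carbon, a 16-fold higher number from compound 1 to compound 4 (1.19 log units; beyond the scatter), which leaves compound 1 alone among the three numbers. On these data alone, whether another group on that aromatic carbon, such as chloro or an amine, would stay near compound 1 or join compound 2 and compound 4 remains open. Nothing shown here explains why the 4-fluorophenyl compound stands apart.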